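Replacing 2-(thiophen-2-yl)ethenyl with pyridin-4-yl on a carbonyl carbon

A few compounds are considered here, and "the series" means these few. Any claim that something is new, unique, unknown or untested is made for them only; others in the source may bear on it.

Compound 1 `C=C1C(=O)O[C@H]2CC3=C[C@H](C/C(C)=C/[C@@H](OC(=O)c4ccc(C(F)(F)F)cc4)[C@H]12)OC3=O` gives > 10000 nM (a limit).
Compound 2 `C=C1C(=O)O[C@H]2CC3=C[C@H](C/C(C)=C/[C@@H](OC(=O)/C=C/c4cccc(OC)c4)[C@H]12)OC3=O` gives > 10000 nM (a limit).
Compound 3 `C=C1C(=O)O[C@H]2CC3=C[C@H](C/C(C)=C/[C@@H](OC(=O)/C=C/c4cccs4)[C@H]12)OC3=O` gives 2900 nM (a measured number).

Compound 3 stands at 2900 nM in a functional assay on NCI-H460 cells (Homo sapiens) for cytotoxicity, read by MTT assay, with a stated time of 48 h (on this read-out lower numbers stand for stronger inhibition and higher numbers for weaker inhibition), and is the only one of the three with a number rather than a limit. The unmeasured compound 4 `C=C1C(=O)O[C@H]2CC3=C[C@H](C/C(C)=C/[C@@H](OC(=O)c4ccncc4)[C@H]12)OC3=O` differs from compound 3 in one place, on a carbonyl carbon: pyridin-4-yl in place of 2-(thiophen-2-yl)ethenyl on a carbonyl carbon. Among the measured compounds shown here, two measured steps bear on this change. Compound 1 is the closest case, with a ring on a carbonyl carbon and no ethenyl chain, and moving to 2-(thiophen-2-yl)ethenyl gave an at least 3.4-fold lower number from compound 1 to compound 3 (0.53 log units; beyond the scatter). Swapping only the ring on the chain gave an at least 3.4-fold lower number from compound 2 to compound 3 (0.53 log units; beyond the scatter). Both sizes are lower bounds, not exact values. Compound 2 keeps an ethenyl chain and still gives only a limit, so the chain alone does not settle the matter. The change at hand reverses the kind of move seen in the first step, so the expected step in this assay is a 2.8-fold higher number from compound 3 to compound 4 (0.44 log units; beyond the scatter), towards weaker inhibition. The estimate for compound 4 is 8000 nM, with an expected range from 3000 nM to 20000 nM, and the reading may well stop at a limit.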

Compound 4, half-maximal inhibitory concentration: 5600 nM
Estimate against measurement, compound 4: 1.4-fold (0.15 log units) above; the measured number falls inside the stated range.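

In this assay, compound 4 shows that a ring set directly on the carbonyl carbon, with no ethenyl chain, can still give a measured number, which the 4-(trifluoromethyl)phenyl ring of compound 1 did not. Exchanging 2-(thiophen-2-yl)ethenyl for pyridin-4-yl gives a 1.9-fold higher number from compound 3 to compound 4 (0.29 log units; within the scatter), so this assay does not separate the two groups, and a measured number at this position does not depend on the ethenyl chain. The comparisons with the other two compounds are an at least 1.7-fold lower number from compound 2 to compound 4 (0.25 log units; that floor lies within the scatter) and an at least 1.7-fold lower number from compound 1 to compound 4 (0.25 log units; that floor lies within the scatter), and these are only floors, so neither shows a real gain on its own: the limit of > 10000 nM in this assay, at which 2 of the 4 values shown sit.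

From the compounds shown here alone, it remains open whether the nitrogen of pyridin-4-yl matters, which a plain phenyl ring or a pyridin-3-yl ring on the same carbonyl carbon would help to settle. Going by these compounds, it is also open how a 2-(pyridin-4-yl)ethenyl group, joining this ring to the chain, or a ring carrying an amine or a carboxylic acid would read in this assay.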